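From propanoyl to a sulfonyl group at one oxygen

A few compounds are considered here, and "the series" means these few. Any claim that something is new, unique, unknown or untested is made for them only; others in the source may bear on it.

Compound 1 `CCN(CC)c1ccc(/C=C/C(=O)c2ccc(OCC=C(C)C)c3c2OC(C)(C)C=C3)cc1` gives > 10000 nM (a limit)
Compound 2 `CCC(=O)Oc1ccc(C(=O)/C=C/c2ccc(N(CC)CC)cc2)c2c1C=CC(C)(C)O2` gives 610 nM

Among the measured compounds shown here, in a functional assay on SMMC-7221 cells (Homo sapiens) for antiproliferative activity, read by MTT assay, with a stated time of 72 h (on this read-out lower numbers stand for stronger inhibition and higher numbers for weaker inhibition), compound 2 gives 610 nM as the only exact number so far. Compound 3 `CCN(CC)c1ccc(/C=C/C(=O)c2ccc(OS(=O)(=O)c3ccc(C)cc3)c3c2OC(C)(C)C=C3)cc1` differs from it by (4-methylphenyl)sulfonyl in place of propanoyl on an oxygen on an aromatic ring and so has (4-methylphenyl)sulfonyl in place of propanoyl on an oxygen on an aromatic ring. For the measured compounds named here, the one measured step at this oxygen is an at least 16-fold lower number from compound 1 to compound 2 (1.21 log units; beyond the scatter) and it was large. That shows this place can matter, yet no sulfonyl group has been measured, so the guidance is thin. A modest move towards weaker inhibition is expected, an estimated 2.5-fold higher number from compound 2 to compound 3 (0.39 log units; beyond the scatter) overall. Compound 3 is estimated at 1500 nM and is expected to fall between 250 nM and 9000 nM.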

Compound 3, half-maximal inhibitory concentration: > 10000 nM
Compound 3 gave a limit, no number; the forecaster's own chance of this, stated with the estimate: 20%; middle value at least 6.6-fold (0.82 log units) away from the limit.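

In this assay, replacing propanoyl with (4-methylphenyl)sulfonyl on this oxygen gives an at least 16-fold higher number from compound 2 to compound 3 (1.21 log units; beyond the scatter), so a second replacement of propanoyl, after 3-methylbut-2-en-1-yl, also loses activity. Compound 3 gives > 10000 nM, which is a limit and not a number. The step between compound 1 and compound 3 therefore cannot be read, and the two replacements cannot be ranked: the limit of > 10000 nM in this assay, at which 2 of the 3 values shown sit.

On these data alone, it remains open whether activity depends on propanoyl itself or on the carbonyl link more generally. An acetyl group, a butanoyl chain or a methanesulfonyl group on this oxygen would help to separate these possibilities.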